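The compounds below may be only part of what the source reports. "The series", "measured", "known", "first", "only" and "open" are said of these compounds alone.

Compound 2 `CC(O)Cn1nnnc1-c1ccccc1-c1ccc(CN2C(=O)[C@H](NC(=O)CC(C)(C)N)CCc3ccccc32)cc1` gives 0.05 uM in a functional assay (Pituitary gland cell) with Rattus norvegicus as the target; a lower number here means that less compound is needed, a higher number that more compound is needed for the effect; compound 1 `CC(C)(N)CC(=O)N[C@@H]1CCc2ccccc2N(Cc2ccc(-c3ccccc3-c3nnnn3CC(=O)O)cc2)C1=O` gives 1 uM.

Compound 2 holds the lowest number of the two, and the gap between them is a 20-fold lower number from compound 1 to compound 2 (1.30 log units; beyond the scatter). Compound 3 `CC(C)(N)CC(=O)N[C@@H]1CCc2ccccc2N(Cc2ccc(-c3ccccc3S(=O)(=O)NC(=O)c3ccccc3)cc2)C1=O` differs from compound 2 by benzoylsulfamoyl in place of 1-(2-hydroxypropyl)-1H-tetrazol-5-yl on an aromatic carbon. Within the data shown here, no measured step concerns this exchange: the only measured step, a 20-fold lower number from compound 1 to compound 2 (1.30 log units; beyond the scatter), alters a different group on the shared core, so it gives no direct guide. The estimate for compound 3 is therefore uncertain, and a step toward a higher number, a 10-fold higher number from compound 2 to compound 3 (1.00 log units; beyond the scatter), is expected. Compound 3 is estimated at 0.5 uM, with a range from 0.08 uM to 3 uM.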

Compound 3, concentration for half-maximal effect: 3 uM
Beside the measured number, compound 3's estimate is 6.0-fold (0.78 log units) below it; the measured number falls inside the stated range.
By their numbers in this assay, from the lowest: compound 2; then compound 1; then compound 3.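

On this aromatic carbon, ortho to a large group, both tetrazoles give lower numbers than benzoylsulfamoyl, but the size of the gap depends on the tetrazole's side chain. Benzoylsulfamoyl replacing the 1-(2-hydroxypropyl)-1H-tetrazol-5-yl group gives a 60-fold higher number from compound 2 to compound 3 (1.78 log units; beyond the scatter) in this assay, while replacing the 1-(carboxymethyl)-1H-tetrazol-5-yl group gives only a 3.0-fold higher number from compound 1 to compound 3 (0.48 log units; beyond the scatter). Nothing available explains why these exchanges differ. Still open, as far as these compounds go, is how a carboxylic acid or an unsubstituted 1H-tetrazol-5-yl group on this carbon would compare.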